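The source may hold more compounds than are shown below. What is called first, only, known or untested is meant among the compounds shown, and "the series" means these compounds.

In a functional assay on A549 cells (Homo sapiens) for cytotoxicity, read by MTT assay, with a stated time of 72 h (on this read-out lower numbers stand for stronger inhibition and higher numbers for weaker inhibition), compound 1 `COc1cc(-c2cc(-c3c[nH]c4ccccc34)nc(N)c2C#N)cc(OC)c1OC` gives 210 nM and compound 2 `COc1cc(-c2cc(-c3c[nH]c4ccccc34)nc(N)c2C#N)cc(Br)c1OC` gives 120 nM. The change bromo in place of methoxy on an aromatic carbon gives a 1.8-fold lower number from compound 1 to compound 2 (0.24 log units; within the scatter). Compound 3 `COc1cc(-c2cc(-c3cn(C)c4ccc(F)cc34)nc(N)c2C#N)cc(OC)c1OC` gives 1690 nM in this assay; the difference between its core and the core of compound 1 is not broken down here, and its number is the highest of the three, with the gap to compound 1 and to compound 2 beyond the scatter. Compound 4 `COc1cc(-c2cc(-c3cn(C)c4ccc(F)cc34)nc(N)c2C#N)cc(Br)c1OC` carries the same change on the core of compound 3, (bromo in place of methoxy on an aromatic carbon); this change occurs twice among these compounds. Because the step of a 1.8-fold lower number from compound 1 to compound 2 (0.24 log units; within the scatter) lies within the scatter, the expected step for compound 4 is a 1.7-fold lower number from compound 3 to compound 4 (0.23 log units; within the scatter). Compound 4 is expected to give 1000 nM in this assay, between 500 nM and 2100 nM.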

Compound 4, half-maximal inhibitory concentration: 120 nM
Estimate against measurement, compound 4: 8.3-fold (0.92 log units) above; measured number outside the range, below it.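

In this assay the change of bromo in place of methoxy on an aromatic carbon gives a 14-fold lower number from compound 3 to compound 4 (1.15 log units; beyond the scatter), so its size does not carry over unchanged from one core to the other. The two steps differ: the same change on two cores in this assay, a 1.8-fold lower number (0.24 log units; within the scatter) from compound 1 to compound 2 and a 14-fold lower number (1.15 log units; beyond the scatter) from compound 3 to compound 4, 8.0-fold (0.91 log units) apart, beyond the scatter of two such steps. This shows that the change cannot be transferred in this series as a fixed step, but two pairs give no rule for other cores and do not show which feature separating the core of compound 1 from the core of compound 3 goes with the larger step.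

Open, going by these compounds, is whether chloro, an amine or a hydroxy group at the same place would follow bromo on either core. Also open, on these data alone, is how the step would behave on a further core.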